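The compounds below may be only part of what the source reports. "The series", "measured", "known", "first", "only" and "open" are said of these compounds alone.

Measured so far in a functional assay on MDA-MB-231 cells (Homo sapiens) for cytotoxicity, read by MTT assay, with a stated time of 48 h; on this read-out higher numbers stand for weaker inhibition and lower numbers for stronger inhibition:

compound 1, `COc1ccc(CN(C(=O)Nc2ccc(Cl)cc2)n2cnnc2)cc1OC`; compound 1 gives > 50000 nM, which is a limit of the assay and not a number.
compound 2, `COc1ccc(OC)c(CN(C(=O)Nc2ccc(C)cc2)n2cnnc2)c1`; compound 2 gives > 50000 nM, again a limit of the assay.
compound 3, `O=C(NCc1ccccc1)N(Cc1ccccn1)n1cnnc1`; compound 3 gives > 50000 nM, again a limit of the assay.

Where compound 3 stands: on the numbers shown it sits at the limit of this assay, and the two further values shown are limits as well (the limit of > 50000 nM in this assay, at which 3 of the 3 values shown sit). Going by the values given here, none of the three is a number, so no ordering of the three can be read, and no step between any two of them can be sized.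

The unmeasured compound is compound 4, `Cc1ccc(NC(=O)N(Cc2ccccn2)n2cnnc2)cc1`. Against compound 3 it differs in one place: 4-methylphenyl in place of benzyl on an amide-type nitrogen. No measured pair shows this change, and the whole of the shown series stands at the limit, so there is nothing from which a direction or a size could be taken.

Expectation: the step of a number no higher from compound 3 to compound 4 (the limit leaves the size open) is expected to be none beyond the scatter. Compound 4 is expected to remain at the limit in this assay, with an estimate of 50000 nM and a range from 20000 nM to 100000 nM, the most likely outcome being that only a limit is reported.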

Compound 4, half-maximal inhibitory concentration: 39500 nM
The estimate for compound 4 lay 1.3-fold (0.10 log units) above the measured number, and the stated range covers the measured number.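

In this assay, compound 4 gives 39500 nM, the only number in the series shown, so this position, on an amide-type nitrogen whose other neighbour is the carbonyl carbon, now has a reading that is not a limit. Placing 4-methylphenyl in place of benzyl, two groups that match in heavy atoms and in their six-membered aromatic ring of carbon, gives an at least 1.2-fold lower number from compound 3 to compound 4 (0.10 log units; that floor lies within the scatter); the starting point of this step is a limit, so the step sets only a floor and leaves its true size unknown. The change therefore brings one compound just inside the measurable range, but the series as a whole remains at the edge of the read-out: the limit of > 50000 nM in this assay, at which 3 of the 4 values shown sit.

As far as these compounds go, whether the reading belongs to the methyl group alone or to the replacement of benzyl as a whole stays open, and the remaining steps cannot be read. Also open, from the compounds shown here alone, is whether an amine or a carboxylic acid on the aromatic ring, or a longer chain in place of the methyl, would move the number further from the limit in this assay.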